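Trimming a Methyl on a Shared Anilinopyrimidine Scaffold

This account rests on a few compounds, and the source may have more. Where it says the series, first, only, none or still open, it means among the compounds named here.

Of the compounds shown here, three have been tested in an ADME assay on HepG2 cells (Homo sapiens) for inhibition, read by fluorescence and resazurin assay, with a stated time of 72 h; on this read-out higher numbers stand for weaker inhibition and lower numbers for stronger inhibition. Compound 1 `CN1CCN(c2ccc(Nc3nccc(Nc4ccc5nc[nH]c5c4)n3)cc2)CC1` gives only a limit in this assay, > 25000 nM; this is the limit of > 25000 nM in this assay, at which 1 of the 3 values shown sits. Compound 2 `Cc1cc(Nc2nccc(Nc3ccc4nc[nH]c4c3)n2)ccc1N1CCN(C)CC1` gives 15000 nM, and compound 3 `Cc1cccc(Nc2ncc(C)c(Nc3ccc4nc[nH]c4c3)n2)c1` gives 6600 nM, the lowest of the two numbers. The difference between the core of compound 2 and that of compound 3 is not broken down here. From compound 2 to compound 1 the change is hydrogen in place of methyl on an aromatic carbon, and the step is an at least 1.6-fold higher number from compound 2 to compound 1 (0.22 log units; that floor lies within the scatter). Compound 4 `Cc1cccc(Nc2nccc(Nc3ccc4nc[nH]c4c3)n2)c1` is not yet measured; it arises from compound 3 by hydrogen in place of methyl on an aromatic carbon, the same kind of change at a different place: on a six-membered aromatic ring with 2 nitrogen rather than one of carbon only, para to a (3-methylphenyl)amino group rather than ortho to a 4-methylpiperazin-1-yl group. The earlier step suggests a modest loss of inhibition from this kind of change. Compound 4 is therefore expected at 12000 nM, an expected step of a 1.8-fold higher number from compound 3 to compound 4 (0.26 log units; within the scatter).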

Compound 4, half-maximal inhibitory concentration: 20000 nM
Estimate against measurement, compound 4: 1.7-fold (0.22 log units) below, and the stated range covers the measured number.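

In this assay, hydrogen in place of methyl gives a 3.0-fold higher number from compound 3 to compound 4 (0.48 log units; beyond the scatter), a real loss of inhibition on this core. Carried to the other core, the size of the same change cannot be pinned down, so these compounds do not show whether it has the same effect on both cores or a different one: the same change on two cores in this assay, an at least 1.6-fold higher number (0.22 log units; that floor lies within the scatter) from compound 2 to compound 1 and a 3.0-fold higher number (0.48 log units; beyond the scatter) from compound 3 to compound 4; the limit leaves it open whether they differ Compound 1 stands at a limit of the assay, > 25000 nM, and not at a number.

Hydrogen in place of 4-methylpiperazin-1-yl gives a 1.3-fold higher number from compound 2 to compound 4 (0.12 log units; within the scatter), a step too small to read as a real difference. The compounds shown leave open what an ethyl group, a methoxy group or an amine in place of the methyl would do to inhibition.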